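Methyl on the terminal phenyl of the urea side chain

The source may hold more compounds than are shown below. What is called first, only, known or untested is meant among the compounds shown, and "the series" means these compounds.

Two compounds of the series have numbers in a functional assay on HepG2 cells (Homo sapiens) for antiproliferative activity, read by MTT assay (on this read-out lower numbers stand for stronger inhibition and higher numbers for weaker inhibition), so far. Compound 1 `CC(C)(C)c1ccc(NC(=O)Nc2cccc(CNc3ncnc4ccccc34)c2)cc1` gives 17000 nM in this assay, and compound 2 `COc1cc2ncnc(NCc3cccc(NC(=O)Nc4ccccc4)c3)c2cc1OC` gives 19700 nM in this assay; the two values lie within the scatter of each other, so no order between them can be read. Compound 3 `COc1cc2ncnc(NCc3cccc(NC(=O)Nc4ccc(C)cc4)c3)c2cc1OC` carries the change methyl in place of hydrogen on an aromatic carbon relative to compound 2, on an aromatic carbon of a six-membered aromatic ring of carbon only. Going by the values given here, with no measured step available for this kind of change, the expected step from compound 2 to compound 3 is a 1.2-fold lower number from compound 2 to compound 3 (0.06 log units; within the scatter), none beyond the scatter. Compound 3 is therefore expected to give about 17000 nM in this assay, between 7000 nM and 40000 nM.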

Compound 3, half-maximal inhibitory concentration: > 50000 nM
Compound 3: no number, only a limit; the forecaster's own chance of this, stated with the estimate: 15%; middle value at least 2.9-fold (0.46 log units) from the limit.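

In this assay compound 3 gives > 50000 nM, which is a limit of the assay and not a number. Methyl in place of hydrogen, para to a large group on the terminal phenyl, brings an at least 2.5-fold higher number from compound 2 to compound 3 (0.40 log units; beyond the scatter), so on this core a single added carbon at this place costs inhibition. The full size of the step cannot be read, since only a limit exists: the limit of > 50000 nM in this assay, at which 1 of the 3 values shown sits.

As far as these compounds go, whether fluorine, hydroxyl or an amine at this place behaves like methyl stays open, as does whether the same step appears on the core of compound 1.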